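Swapping the aryl group on a shared core: compound 4

The compounds below may be only part of what the source reports. "The series", "measured", "known", "first", "only" and "open" are said of these compounds alone.

Measured compounds:
compound 1, `CCC1=C(O)c2c(oc(-c3ccc(SC)cc3)cc2=O)C(CC)(CC)C1=O`, 1.38 uM
compound 2, `CCC1=C(O)c2c(oc(-c3ccccc3C)cc2=O)C(CC)(CC)C1=O`, 2.41 uM
compound 3, `CCC1=C(O)c2c(oc(-c3ccccc3F)cc2=O)C(CC)(CC)C1=O`, 3.93 uM

All three share one core and differ only in the aryl group that hangs from it. In a functional assay on KBVIN cells (Homo sapiens) for antiproliferative activity, read by sulforhodamine B assay, with a stated time of 3 days (on this read-out higher numbers stand for an effect only at larger amounts of compound and lower numbers for an effect already at smaller amounts), compound 3 gives 3.93 uM, the highest of the three numbers; the steps leading up to it are a 1.6-fold higher number from compound 2 to compound 3 (0.21 log units; within the scatter) and a 2.8-fold higher number from compound 1 to compound 3 (0.45 log units; beyond the scatter).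

Compound 4, `CCC1=C(O)c2c(oc(-c3ccc(OC)c(Cl)c3)cc2=O)C(CC)(CC)C1=O`, has not yet been measured. The change from compound 3 is 3-chloro-4-methoxyphenyl in place of 2-fluorophenyl on an aromatic carbon.

Two measured steps inform this. Replacing 4-(methylsulfanyl)phenyl with 2-fluorophenyl gave a 2.8-fold higher number from compound 1 to compound 3 (0.45 log units; beyond the scatter), a modest rise. Replacing 4-(methylsulfanyl)phenyl with 2-methylphenyl gave a 1.7-fold higher number from compound 1 to compound 2 (0.24 log units; within the scatter), within the scatter. The 3-chloro-4-methoxyphenyl entering in compound 4 resembles the group of compound 1 more than the 2-fluorophenyl it replaces, so a modest fall in the number, back toward compound 1, is expected, though the substitution pattern is new and the step could also vanish within the scatter.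

For compound 4 the estimate in this assay is 1.8 uM, with a range from 0.9 uM to 3.6 uM, meaning an expected step of a 2.2-fold lower number from compound 3 to compound 4 (0.34 log units; beyond the scatter).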

Compound 4, concentration for half-maximal effect: 1.37 uM
Estimate against measurement, compound 4: 1.3-fold (0.12 log units) above; the measured number falls inside the stated range.
By their numbers in this assay, from the lowest: compounds 4, 1, 2 and 3 (each within the scatter of the next, the first and the last beyond it).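

Putting 3-chloro-4-methoxyphenyl in place of 2-fluorophenyl gives a 2.9-fold lower number from compound 3 to compound 4 (0.46 log units; beyond the scatter) in this assay, so this position accepts an aryl group with more heavy atoms, and one with a hydrogen-bond acceptor, with no rise in the number. The same group in place of 4-(methylsulfanyl)phenyl gives a 1.0-fold lower number from compound 1 to compound 4 (0.00 log units; within the scatter), and in place of 2-methylphenyl it gives a 1.8-fold lower number from compound 2 to compound 4 (0.25 log units; within the scatter), so among these four compounds, 2-fluorophenyl stands apart only from the groups of compound 1 and compound 4, while compound 2 cannot be separated from either of them. Nothing given here explains why these aryl groups fall as they do.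

Still open, as far as these compounds go, is what the chloro and the methoxy each contribute, which a phenyl ring carrying only one of them, such as 4-methoxyphenyl or 3-chlorophenyl, could begin to separate. Also open, from the compounds shown here alone, is how this position in this assay would respond to an aryl group carrying an amine or a carboxylic acid, or to a saturated ring such as cyclohexyl in place of the aryl ring.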